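The compounds below may be only part of what the source reports. "The series", "measured", "known", "first", "only" and "open" are said of these compounds alone.

Measured compounds:
compound 1 `Brc1cccc(Sc2ncccc2OCCCc2ccncc2)c1` — 50%
compound 2 `Brc1cccc(Oc2ncccc2OCCCc2ccncc2)c1` — 23%

Compound 1 stands highest of the two numbers in a functional assay on the whole organism for inhibition, with Mus musculus as the target, with stated times of 2 days and 30 min, at a dose of 10 mg/kg by the oral route; on this read-out higher numbers stand for more inhibition at the one dose given (going by the name of the read-out) and lower numbers for less inhibition. Its nearest neighbour is compound 2, which differs by 3-bromophenoxy in place of (3-bromophenyl)sulfanyl on an aromatic carbon; that change gave a number 27 percentage points lower from compound 1 to compound 2 (beyond the scatter), a modest move beyond the scatter.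

Compound 3 `Oc1cnccc1CCCOc1cccnc1Sc1cccc(Br)c1` is not yet measured. It differs from compound 1 by hydroxy in place of hydrogen on an aromatic carbon. For the measured compounds named here, this change sits on a different ring from the one altered between compound 1 and compound 2, so no measured step speaks directly to it. Going by the values given here, the only step available, from compound 1 to compound 2, was modest, which suggests that single changes on this core tend to move this assay by a modest amount or not beyond the scatter at all.

Among the compounds with values here, with no direct precedent, compound 3 is expected to stay near compound 1, giving an estimated 45% with a range of 20% to 70%. The estimated step of a number 5 percentage points lower from compound 1 to compound 3 (within the scatter) is expected to lie within or only just beyond the scatter, in either direction.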

Compound 3, a percentage reported as inhibition, in the whole organism at one dose (the size of the read-out at that dose, not a potency): 33%
Beside the measured number, compound 3's estimate is 12 percentage points above it; measured number inside the range.
By their numbers in this assay, from the lowest: compounds 2 and 3 (each within the scatter of the next); then compound 1.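

In this assay, hydroxy in place of hydrogen on an aromatic carbon of the six-membered aromatic ring with 1 nitrogen, ortho to a large group and two atoms from the ring nitrogen, gives a number 17 percentage points lower from compound 1 to compound 3 (beyond the scatter). This position, untouched by the earlier step, therefore responds to substitution: a group of 1 heavy atom is enough to carry the read-out beyond the scatter, and in the same direction as the change to 3-bromophenoxy, which gave a number 27 percentage points lower from compound 1 to compound 2 (beyond the scatter), so compound 1 keeps the highest number among its two single-change neighbours. Nothing available bears on why hydroxy at this place lowers the number.

The compounds shown leave open whether this loss belongs to hydroxy itself or to any group at this position, a question that a methoxy group, a fluorine atom or an amine at the same place on compound 1 would address. They also leave open whether a longer chain between the shared core and this ring would alter the response to hydroxy at this position.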